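The source may report more compounds than this note shows. Statements on the series, on what has been measured and on what is new or still open speak of the compounds shown alone.

Measured compounds and their values:
compound 1 `Nc1cc(N)c2nc(-c3ccccc3)c(NCc3ccc(Cl)c(Cl)c3)nc2c1` – in a functional assay on KM12 cells (Homo sapiens) for inhibition, read by sulforhodamine B assay, with a stated time of 48 h (on this read-out higher numbers stand for weaker inhibition of growth and lower numbers for stronger inhibition of growth), compound 1 gives 3390 nM
compound 2 `CCOC(=O)[C@H](CCC(=O)O)NC(=O)c1ccc(Sc2nc3cc(N)cc(N)c3nc2-c2ccccc2)cc1` – compound 2 gives 24000 nM
compound 3 `COc1ccc(Sc2nc3cc(N)cc(N)c3nc2-c2ccccc2)cc1` – compound 3 gives 28200 nM

Compound 3 holds the highest of the three numbers shown. Its gap to compound 2 lies within the usual scatter, while compound 1 stands well beyond it with the lower number. Compound 4 `Nc1cc(N)c2nc(-c3ccccc3)c(Sc3ccc(F)cc3)nc2c1` differs from compound 3 by fluoro in place of methoxy on an aromatic carbon. Within the data shown here, no pair of measured compounds shows this same change, so nothing here tells how much a fluoro in place of methoxy matters; the expectation is for a step no larger than the scatter, in no settled direction, written as a 1.1-fold lower number from compound 3 to compound 4 (0.05 log units; within the scatter). Compound 4 is therefore expected to give about 25000 nM, estimated between 10000 nM and 60000 nM in this assay.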

Compound 4, concentration for 50% growth inhibition: 20900 nM
For compound 4 the middle estimate is 1.2-fold (0.08 log units) above the measured one, within the range that was stated.
By their numbers in this assay, from the lowest: compound 1; then compounds 4, 2 and 3 (each within the scatter of the next).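

In this assay, fluoro in place of methoxy on this aromatic carbon, para to a large group, gives a 1.3-fold lower number from compound 3 to compound 4 (0.13 log units; within the scatter). At this position, then, the two groups cannot be told apart on this read-out, although methoxy has more heavy atoms and a hydrogen-bond acceptor. Nothing measured here offers a cause for this result. As far as these compounds go, whether an amine, a carboxylic acid or a longer chain at this position would shift the number beyond the scatter stays open. No pair shown isolates the sulfanyl link either.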